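Removing the methyl on the saturated ring carbon of compound 3

The compounds below may be only part of what the source reports. "The series", "measured", "known", "first", "only" and "open" are said of these compounds alone.

Compound 3 `CCOC(=O)Nc1ccc(S(=O)(=O)N2C(=O)N[C@@H](c3ccccc3)C2C)cc1Cl` gives the highest number of the three measured in a functional assay on A549 cells (Homo sapiens) for cytotoxicity, read by MTT assay (a higher number here means a weaker inhibitor, a lower number a stronger inhibitor), at 6000 nM. Compound 2 `CCCCOC(=O)Nc1ccc(S(=O)(=O)N2C[C@H](c3ccccc3)NC2=O)cc1CC` gives 200 nM, and compound 1 `CCCOC(=O)Nc1ccc(S(=O)(=O)N2C[C@H](c3ccccc3)NC2=O)cc1CC` gives 60 nM; both lack a methyl on the saturated ring carbon of the shared core. Compound 4 `CCOC(=O)Nc1ccc(S(=O)(=O)N2C[C@H](c3ccccc3)NC2=O)cc1Cl` differs from compound 3 by hydrogen in place of methyl on a saturated ring carbon. For the measured compounds named here, the only measured step, a 3.3-fold higher number from compound 1 to compound 2 (0.52 log units; beyond the scatter), concerns the carbamate chain and not the ring carbon, so no measured step bears directly on this change. Compounds 1 and 2 sit far below compound 3, but they also differ in the aryl substituent and the carbamate chain, so the expectation is loose. Compound 4 is expected to give a lower number, by a 4.0-fold lower number from compound 3 to compound 4 (0.60 log units; beyond the scatter), estimated at 1500 nM within 300 nM to 6000 nM.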

Compound 4, half-maximal inhibitory concentration: 20 nM
The estimate for compound 4 lay 75-fold (1.88 log units) above the measured number, outside the stated range (below it).
By their numbers in this assay, from the lowest: compound 4; then compound 1; then compound 2; then compound 3.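

Hydrogen in place of methyl on this saturated ring carbon, next to the ring atom that bears a phenyl group, gives in this assay a 300-fold lower number from compound 3 to compound 4 (2.48 log units; beyond the scatter), the first step measured at this position. It is much larger than the carbamate chain step, a 3.3-fold higher number from compound 1 to compound 2 (0.52 log units; beyond the scatter), so a single carbon at this ring position can shift the number more than that chain change. No measured evidence accounts for the size of this step.

Open, as far as these compounds go, is how an ethyl or hydroxymethyl group on this ring carbon would read. Also open, from the compounds shown here alone, is whether methyl here has a similar effect with the aryl substituent and carbamate chain of compound 1.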